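This account rests on a few compounds, and the source may have more. Where it says the series, first, only, none or still open, it means among the compounds named here.

Of the compounds shown here, three have so far been tested in a functional assay on HL-60 cells (Homo sapiens) for inhibition, read by MTT assay, with a stated time of 72 h; a higher number here means a weaker inhibitor, a lower number a stronger inhibitor. Compound 1 `Cc1ccc(N2CCN(C(=O)c3oc(C)nc3-c3ccccc3)CC2)cc1` carries a 4-methylphenyl on an amine nitrogen in a ring. In this assay compound 1 gives > 1000 nM, which is a limit of the assay and not a number. Compound 1 thus sits at the limit of > 1000 nM in this assay, at which 1 of the 3 values shown sits. Compound 2 `CCCc1nc(-c2ccc(OC)c(OC)c2)c(C(=O)N2CCN(c3cccc(Cl)c3)CC2)o1` is reported in this assay as "not active" (no number reported), again without a number. Among the compounds with values here, compound 3 `CCc1nc(-c2ccc(F)cc2)c(C(=O)N2CCN(c3cccc(Cl)c3)CC2)o1`, the only one with a measured number, gives 169 nM in this assay. Within the data shown here, compounds 2 and 3 differ from compound 1 in several places at once, so no single step between measured compounds can be read from these data.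

Compound 4 `CCOc1cccc(N2CCN(C(=O)c3oc(C)nc3-c3ccccc3)CC2)c1` is the new entry. It differs from compound 1 in one place: 3-ethoxyphenyl in place of 4-methylphenyl on an amine nitrogen in a ring. With only a limit for compound 1, the size of the step is hard to judge. The expectation is that compound 4 stays weak. Compound 4 is expected to give 2000 nM in this assay, within 500 nM to 10000 nM. The step that the limit leaves unreadable from compound 1 to compound 4 is expected to lie within the usual scatter.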

Compound 4, half-maximal inhibitory concentration: 151 nM
For compound 4 the middle estimate is 13-fold (1.12 log units) above the measured one, outside the stated range (below it).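

In this assay, 3-ethoxyphenyl in place of 4-methylphenyl on an amine nitrogen in a ring gives an at least 6.6-fold lower number from compound 1 to compound 4 (0.82 log units; beyond the scatter). Within the data shown here, this is the one change in these compounds that can be read on its own, and it shows that the group at this position can alone move the read-out by more than the scatter, with the rest of the molecule unchanged. The true size of the step stays unknown, since the value for compound 1 is a limit of the assay and not a number: the limit of > 1000 nM in this assay, at which 1 of the 4 values shown sits.

The compounds shown leave open whether the ethoxy group itself or its place on the phenyl ring matters more, as the two groups differ in both. From the compounds shown here alone, a methoxy group or a longer chain in place of the ethoxy group also remains open.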